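The source may report more compounds than this note shows. Statements on the series, on what has been measured and on what is new or still open speak of the compounds shown alone.

Compound 1 `Nc1ccccc1NC(=O)c1ccc(CSC(=S)N2CCN(c3ccccc3)CC2)cc1` gives 88.6% in a functional assay on A-375 cells (Homo sapiens) for antiproliferative activity, read by CCK-8 assay, with a stated time of 72 h, tested at 8 uM; on this read-out lower numbers stand for a weaker effect and higher numbers for a stronger effect at the one concentration tested. Compound 2 `COc1ccc(N2CCN(C(=S)SCc3ccc(C(=O)Nc4ccccc4N)cc3)CC2)cc1` gives 35.9% in this assay, the lower of the two numbers; the step of a number 52.7 percentage points lower from compound 1 to compound 2 (beyond the scatter) lies beyond the scatter. Compound 3 `N#Cc1ccc(N2CCN(C(=S)SCc3ccc(C(=O)Nc4ccccc4N)cc3)CC2)cc1` differs from compound 2 by cyano in place of methoxy on an aromatic carbon. Among the compounds with values here, the one measured step shows that a group entering on this aromatic carbon reduced inhibition, but no step speaks to cyano itself, so the direction for compound 3 is uncertain. For compound 3 an inhibition of 50% is estimated, between 20% and 85%. The estimate means a step of a number 14.1 percentage points higher from compound 2 to compound 3 (beyond the scatter) in this assay, expected to stay close to the scatter.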

Compound 3, a percentage reported as inhibition, at one concentration (the size of the read-out at that concentration, not a potency): 62.9%
Compound 3: middle estimate off by 12.9 percentage points, on the low side; the measured number falls inside the stated range.
By their numbers in this assay, from the lowest: compound 2; then compound 3; then compound 1.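

The change from 4-methoxyphenyl to 4-cyanophenyl shows that this position does not respond in one direction only: this assay records a number 27 percentage points higher from compound 2 to compound 3 (beyond the scatter), so the outcome depends on which group enters, not merely on a group being present. Cyano still does not restore the effect seen with hydrogen at this place, leaving a number 25.7 percentage points lower from compound 1 to compound 3 (beyond the scatter) in the same read-out. Nothing available explains the difference between these groups. From the compounds shown here alone, whether an amine or a carboxylic acid at this place would match hydrogen remains open.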